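Swapping the aryl group on a shared core

This account rests on a few compounds, and the source may have more. Where it says the series, first, only, none or still open, it means among the compounds named here.

Measured compounds:
- compound 1 `N#Cc1ccccc1-c1cc(F)cc(-n2nnc(-c3ccccn3)n2)c1` — 4 nM
- compound 2 `Nc1ccccc1-c1cc(F)cc(-n2nnc(-c3ccccn3)n2)c1` — 7 nM
- compound 3 `Cc1cccnc1-c1cc(F)cc(-n2nnc(-c3ccccn3)n2)c1` — 24 nM

In an assay for binding affinity to metabotropic glutamate receptor 5 (Rattus norvegicus) (on this read-out higher numbers stand for weaker inhibition and lower numbers for stronger inhibition), compound 2 stands second highest of the three numbers. Its closest neighbour is compound 1, with a 1.8-fold higher number from compound 1 to compound 2 (0.24 log units; within the scatter); its furthest is compound 3, with a 3.4-fold higher number from compound 2 to compound 3 (0.54 log units; beyond the scatter).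

The unmeasured compound 4 `Cc1ncccc1-c1cc(F)cc(-n2nnc(-c3ccccn3)n2)c1` arises from compound 2 by 2-methylpyridin-3-yl in place of 2-aminophenyl on an aromatic carbon. The measured steps that bear on this are those in which the 2-aminophenyl or 2-cyanophenyl group was exchanged for a methyl-bearing pyridyl group: a 3.4-fold higher number from compound 2 to compound 3 (0.54 log units; beyond the scatter) and a 6.0-fold higher number from compound 1 to compound 3 (0.78 log units; beyond the scatter). Both moved the number modestly upward, beyond the scatter. Going by the values given here, the group entering compound 4 is a different pyridyl isomer from that in compound 3, so no measured pair matches it exactly, and the outcome is less certain.

On this basis a modest rise is expected for compound 4, a 2.9-fold higher number from compound 2 to compound 4 (0.46 log units; beyond the scatter). The estimated value of compound 4 in this assay is 20 nM, with a range from 6 nM to 70 nM.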

Compound 4, inhibition constant: 45 nM
Beside the measured number, compound 4's estimate is 2.3-fold (0.35 log units) below it, and the stated range covers the measured number.
By their numbers in this assay, from the lowest: compounds 1 and 2 (each within the scatter of the next); then compounds 3 and 4 (each within the scatter of the next).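

In this assay, this aromatic carbon clearly separates the aryl groups: replacing 2-aminophenyl with 2-methylpyridin-3-yl gives a 6.4-fold higher number from compound 2 to compound 4 (0.81 log units; beyond the scatter), and replacing the nitrile-bearing ring of compound 1 with the same group gives a large step, an 11-fold higher number from compound 1 to compound 4 (1.05 log units; beyond the scatter). The two methyl-bearing pyridyl groups cannot be told apart, however, with a 1.9-fold higher number from compound 3 to compound 4 (0.27 log units; within the scatter), so both compound 3 and compound 4 give higher numbers than compound 1 and compound 2, while the choice between these two isomers makes no clear difference. Nothing available here explains why these groups differ.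

The compounds shown leave open whether the higher numbers go with the ring nitrogen or with the methyl group. A 2-methylphenyl group or an unsubstituted pyridyl group at this position would help separate the two.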